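The source may report more compounds than this note shows. Statements on the series, on what has been measured and on what is new or still open speak of the compounds shown alone.

All three measured compounds were tested in a functional assay on Jurkat cells for inhibition of nuclear factor NF-kappa-B complex (Homo sapiens); a lower number here means a stronger inhibitor, a higher number a weaker inhibitor:

compound 1, `CCOC(=O)c1cnc(-c2cnc3ccccc3c2)nc1NN1C(=O)C=C(C)C1=O`: 6000 nM
compound 2, `CCOC(=O)c1cnc(-c2cccc(Br)c2)nc1NN1C(=O)C=C(C)C1=O`: 700 nM
compound 3, `CCOC(=O)c1cnc(C2CC2)nc1NN1C(=O)C=C(C)C1=O`: 1000 nM

Among these three numbers compound 3 stands second highest. Its nearest neighbour is compound 2, and the step of a 1.4-fold higher number from compound 2 to compound 3 (0.15 log units; within the scatter) lies within the usual scatter; its furthest is compound 1, with a 6.0-fold lower number from compound 1 to compound 3 (0.78 log units; beyond the scatter) clearly beyond it. Compound 4, `CCOC(=O)c1cnc(Cc2ccccc2)nc1NN1C(=O)C=C(C)C1=O`, differs from compound 3 in one place: benzyl in place of cyclopropyl on an aromatic carbon.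

Within the data shown here, two measured steps bear on this. Going from the quinolin-3-yl of compound 1 to a smaller group gave lower numbers in both an 8.6-fold lower number from compound 1 to compound 2 (0.93 log units; beyond the scatter) and a 6.0-fold lower number from compound 1 to compound 3 (0.78 log units; beyond the scatter), while the exchange of 3-bromophenyl for cyclopropyl, a 1.4-fold higher number from compound 2 to compound 3 (0.15 log units; within the scatter), changed little. Benzyl brings back a six-membered aromatic ring of carbon only, as in compound 2, so the step of no change at the digits printed from compound 3 to compound 4 (within the scatter) is expected to stay within the scatter. Compound 4 is therefore estimated at 1000 nM, with a range from 300 nM to 4000 nM.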

Compound 4, half-maximal inhibitory concentration: 7000 nM
Estimate against measurement, compound 4: 7.0-fold (0.85 log units) below; the measured number lies above the stated range.
By their numbers in this assay, from the lowest: compounds 2 and 3 (each within the scatter of the next); then compounds 1 and 4 (each within the scatter of the next).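

At this position, on the aromatic carbon between two ring nitrogen atoms, having a six-membered aromatic ring of carbon only does not settle the outcome in this assay: there is a 10-fold higher number from compound 2 to compound 4 (1.00 log units; beyond the scatter), although both groups contain such a ring. The earlier compounds shown here showed little change on exchanging 3-bromophenyl for cyclopropyl, but benzyl, whose ring is joined through a carbon linker rather than directly, gives a 7.0-fold higher number from compound 3 to compound 4 (0.85 log units; beyond the scatter). With a 1.2-fold higher number from compound 1 to compound 4 (0.07 log units; within the scatter), benzyl and quinolin-3-yl fall together, apart from 3-bromophenyl and cyclopropyl, so this position responds strongly to some exchanges and hardly at all to others.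

Nothing available explains this difference. As far as these compounds go, whether the linker or the missing bromine matters more stays open, as an unsubstituted phenyl group would separate the two, and an amine or a longer chain here remains equally uncertain.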